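The compounds below may be only part of what the source reports. "The series", "measured", "known", "first", "only" and "open" are said of these compounds alone.

Measured so far in a functional assay on SW707 cells (Homo sapiens) for cytotoxicity, read by sulforhodamine B assay, with a stated time of 72 h; on this read-out higher numbers stand for weaker inhibition and lower numbers for stronger inhibition:
compound 1, `OCC#CCSc1cnc2ccccc2c1Cl`: 6.2 ug/mL
compound 2, `OCC#CCSc1cnc2ccccc2c1[Se]CC#CCBr`: 2.8 ug/mL
compound 3, `OCC#CCSc1cnc2ccccc2c1SCC#CCO`: 32 ug/mL

Compound 3 stands highest of the three; its nearest neighbour is compound 1 (a 5.2-fold higher number from compound 1 to compound 3 (0.71 log units; beyond the scatter)), its furthest compound 2 (an 11-fold higher number from compound 2 to compound 3 (1.06 log units; beyond the scatter)). Compound 4, `C[Se]c1c(SCC#CCO)cnc2ccccc12`, differs from compound 3 by a group of 2 heavy atoms (1 carbon, 1 selenium; no ring) in place of a group of 6 heavy atoms (4 carbon, 1 oxygen, 1 sulfur; no ring), on an aromatic carbon. Going by the values given here, two measured steps bear on this: the group that leaves in compound 4 is the one that entered in both a 5.2-fold higher number from compound 1 to compound 3 (0.71 log units; beyond the scatter) and an 11-fold higher number from compound 2 to compound 3 (1.06 log units; beyond the scatter), and each entry raised the number, modestly and then largely. Its removal is therefore expected to lower the number again, and the entering group carries selenium, as does compound 2, which holds the lowest value. For compound 4 a step of a 6.4-fold lower number from compound 3 to compound 4 (0.81 log units; beyond the scatter) is expected, to an estimated 5 ug/mL (range 2 ug/mL to 15 ug/mL) in this assay.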

Compound 4, concentration for 50% inhibition: 3.5 ug/mL
For compound 4 the middle estimate is 1.4-fold (0.15 log units) above the measured one; the range from low to high includes it.
By their numbers in this assay, from the lowest: compounds 2, 4 and 1 (each within the scatter of the next, the first and the last beyond it); then compound 3.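

In this assay, the group of 2 heavy atoms (1 carbon, 1 selenium) on this aromatic carbon gives a 9.1-fold lower number from compound 3 to compound 4 (0.96 log units; beyond the scatter) in place of the sulfur-bearing chain, so a much smaller group reverses the rise that chain produced. Potency at this position does not depend on the bromine-ended chain on selenium, as its loss gives a 1.3-fold higher number from compound 2 to compound 4 (0.10 log units; within the scatter) and is within the scatter; chlorine at the same carbon also stays within the scatter, with a 1.8-fold lower number from compound 1 to compound 4 (0.25 log units; within the scatter) as the step. No available evidence gives a cause for these steps.

Open, from the compounds shown here alone, is whether a methylthio group on this carbon would match compound 4, which would separate the role of selenium from that of group size. Going by these compounds, how an amine at this position would read also remains open.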